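The source may report more compounds than this note shows. Statements on the series, on what has been measured and on what is new or still open speak of the compounds shown alone.

Measured compounds in a functional assay on OVCAR-5 cells (Homo sapiens) for cytotoxicity, read by sulforhodamine B assay, with a stated time of 48 h; on this read-out higher numbers stand for weaker inhibition of growth and lower numbers for stronger inhibition of growth:

compound 1 `ClCc1ccccc1Cn1cnc2c(Cl)nc(Cl)nc21` – 1580 nM
compound 2 `ClCc1ccc(Cn2cnc3nc(Cl)nc(Cl)c32)cc1` – 2180 nM
compound 3 `ClCc1ccccc1Cn1cnc2ncnc(Cl)c21` – 2810 nM

Compound 1 gives the lowest of the three numbers, but its gaps to compound 2 and to compound 3 both lie within the usual scatter of this assay, so no order among the three can be claimed from these values alone. Among the compounds with values here, no pair of the measured compounds differs in one place only, so no single structural step has yet been measured in this assay.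

The next compound, compound 4 `Nc1nc(Cl)c2ncn(Cc3ccccc3CCl)c2n1`, is compound 1 with amino in place of chloro on an aromatic carbon. Within the data shown here, no measured step in this assay speaks to this change, and the three values so far give no footing for either direction. The working expectation is a step of no more than the scatter, with a slight lean towards a higher number. For compound 4 the estimate in this assay is 2500 nM, with a range of 800 nM to 8000 nM. This means an expected step of a 1.6-fold higher number from compound 1 to compound 4 (0.20 log units; within the scatter).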

Compound 4, concentration for 50% growth inhibition: 20000 nM
For compound 4 the middle estimate is 8.0-fold (0.90 log units) below the measured one, and the stated range ends below it.
By their numbers in this assay, from the lowest: compounds 1, 2 and 3 (each within the scatter of the next); then compound 4.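

Amino in place of chloro on the aromatic carbon between two ring nitrogen atoms gives a 13-fold higher number from compound 1 to compound 4 (1.10 log units; beyond the scatter) in this assay, the first step in this series that can be read as a single change. This carbon is therefore not indifferent to its substituent: one exchange of a single heavy atom here is enough to carry the number beyond the scatter. The data shown offer nothing that accounts for the size of this step.

From the compounds shown here alone, whether a methoxy group or a dimethylamino group on this carbon would give a number near that of compound 1 or near that of compound 4 remains open. Also open, going by these compounds, is whether amino in place of chloro at this carbon would give a step of similar size on compound 2.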